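Swapping the nitrogen substituent: from 2-methoxyphenyl to benzyl

The compounds below may be only part of what the source reports. "The series", "measured", "known", "first", "only" and "open" are said of these compounds alone.

Compound 1 `Cc1ccc2nc(NC(=O)CSc3nc4c(c(=O)n3-c3ccc(F)cc3)SCC4)sc2c1`: 5340 nM
Compound 2 `COc1ccccc1-n1c(SCC(=O)Nc2nc3ccc(C)cc3s2)nc2c(c1=O)SCC2`: 230 nM

Going by the values given here, in a functional assay on MIA PaCa-2 cells (Homo sapiens) for antiproliferative activity, read by MTT assay, with a stated time of 48 h (on this read-out higher numbers stand for an effect only at larger amounts of compound and lower numbers for an effect already at smaller amounts), compound 2 gives 230 nM, the lower of the two numbers measured so far. Compound 3 `Cc1ccc2nc(NC(=O)CSc3nc4c(c(=O)n3Cc3ccccc3)SCC4)sc2c1` carries benzyl in place of 2-methoxyphenyl on an aromatic nitrogen. Among the compounds with values here, one measured step bears on this place: a 23-fold lower number from compound 1 to compound 2 (1.37 log units; beyond the scatter). Within the data shown here, that step is large and shows how far the number can move with a change here, but it is the only guide. A moderate step towards a higher number is expected in this assay, with compound 2 at the low end so far. The expected change is a 4.3-fold higher number from compound 2 to compound 3 (0.64 log units; beyond the scatter). The estimated value for compound 3 is 1000 nM, with an expected range from 200 nM to 5000 nM.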

Compound 3, half-maximal effective concentration: 5650 nM
Beside the measured number, compound 3's estimate is 5.7-fold (0.75 log units) below it; measured number above the stated range.
By their numbers in this assay, from the lowest: compound 2; then compounds 1 and 3 (each within the scatter of the next).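

In this assay, the low number of compound 2 does not carry over to benzyl at this nitrogen: the change gives a 25-fold higher number from compound 2 to compound 3 (1.39 log units; beyond the scatter). Benzyl and 4-fluorophenyl cannot be told apart here, with a 1.1-fold higher number from compound 1 to compound 3 (0.02 log units; within the scatter). Among these three groups, then, only 2-methoxyphenyl stands apart at this position.

On these data alone, what an unsubstituted phenyl, a 2-methoxybenzyl or a longer chain such as phenethyl would give at this nitrogen stays open. Nothing at hand gives a reason for the gap between 2-methoxyphenyl and the other two groups.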